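A few compounds are considered here, and "the series" means these few. Any claim that something is new, unique, unknown or untested is made for them only; others in the source may bear on it.

Measured so far:
- compound 1, `COc1ccc(-c2cc(/C=C/C(=O)c3ccc(N)cc3)[nH]n2)cc1`, -94%
- compound 2, `COc1cc(-c2cc(/C=C/C(=O)c3ccc(N)cc3)[nH]n2)cc(OC)c1OC`, -96%

Both compounds were tested in a functional assay on U-251 cells (Homo sapiens) for cytotoxicity, read by sulforhodamine B assay, with a stated time of 48 h, tested at 10 uM; on this read-out higher numbers stand for a weaker effect at the one concentration tested and lower numbers for a stronger effect. Compound 1 gives -94%, and compound 2 gives -96%. The two numbers lie within the usual scatter of repeated measurements of each other, so compound 2 stands alongside compound 1 rather than apart from it, and neither can be called the stronger.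

Compound 3, `COc1ccc(-c2cc(/C=C/C(=O)c3ccc(N)cc3)[nH]n2)cc1OC`, has not yet been measured. It differs from compound 2 in one place: hydrogen in place of methoxy on an aromatic carbon. Because compound 1 gives -94% and compound 2 gives -96% despite carrying different numbers of methoxy groups, the step from compound 2 to compound 3 is expected to be small, likely none beyond the scatter, with at most a slight weakening. Compound 3 is therefore expected to give about -92%, in a range of -100% to -70%, which means an expected step of a number 4 percentage points higher from compound 2 to compound 3 (within the scatter).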

Compound 3, a percentage reported as activity, at one concentration (the size of the read-out at that concentration, not a potency): -68%
The estimate for compound 3 lay 24 percentage points below the measured number, and the stated range ends below it.
By their numbers in this assay, from the lowest: compounds 2 and 1 (each within the scatter of the next); then compound 3.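

Swapping a single methoxy for hydrogen on the aromatic carbon ortho to a methoxy group and meta to a large group changes the result in this assay: the read-out shows a number 28 percentage points higher from compound 2 to compound 3 (beyond the scatter), so the effect weakens. Adding a methoxy to compound 1 also weakens it, with a number 26 percentage points higher from compound 1 to compound 3 (beyond the scatter), so among these three compounds the effect does not follow the number of methoxy groups in one direction, and what counts is which carbons carry them. No measurement here explains this shift.

On these data alone, whether a hydroxy group or a chlorine atom on this carbon would behave like methoxy or like hydrogen remains open. With only one concentration tested, the relative potency of these compounds also remains unknown.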